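Adding an Amino Group to the Core of Compound 1

The source may report more compounds than this note shows. Statements on the series, on what has been measured and on what is new or still open speak of the compounds shown alone.

Compound 1 `COc1ncnc2c1c(-c1cccs1)cn2[C@@H]1O[C@H](CO)[C@@H](O)[C@H]1O` is the reference point here. In a functional assay on HL-60 cells (Homo sapiens) for antiproliferative activity, read by XTT assay, with a stated time of 72 h (a lower number here means a stronger inhibitor, a higher number a weaker inhibitor), compound 1 gives 80 nM, the lowest of the two numbers obtained. Its nearest neighbour is compound 3 `COc1ncnc2c1c(-c1ccoc1)cn2[C@@H]1O[C@H](CO)[C@@H](O)[C@H]1O`, which in this assay gives 150 nM, and the exchange gives a 1.9-fold higher number from compound 1 to compound 3 (0.27 log units; within the scatter). Compound 2 `CNc1ncnc2c1c(-c1cccs1)cn2[C@@H]1O[C@H](CO)[C@@H](O)[C@H]1O` reaches only a limit of the assay: in this assay compound 2 gives > 20000 nM. That is the limit of > 20000 nM in this assay, at which 1 of the 3 values shown sits. The change there amounts to an at least 250-fold higher number from compound 1 to compound 2 (2.39 log units; beyond the scatter).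

Compound 4 `COc1nc(N)nc2c1c(-c1cccs1)cn2[C@@H]1O[C@H](CO)[C@@H](O)[C@H]1O` differs from compound 1 by amino in place of hydrogen on an aromatic carbon. Neither measured step repeats this change: the step to compound 2 exchanges one group for another on a different aromatic carbon, and the step to compound 3 alters the five-membered ring. The collapse in compound 2 shows that the six-membered ring of the core is sensitive to alteration, while the small shift in compound 3 shows tolerance elsewhere. Compound 4 is therefore expected to show a 3.8-fold higher number from compound 1 to compound 4 (0.57 log units; beyond the scatter), a step beyond the scatter but far short of the loss seen with compound 2. Compound 4 is estimated at 300 nM, with a range from 60 nM to 2000 nM.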

Compound 4, half-maximal inhibitory concentration: > 20000 nM
Compound 4: only a limit was reported (the forecaster's own chance of this, stated with the estimate: 10%); at least 66-fold (1.82 log units) between middle value and limit.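

On the aromatic carbon between two ring nitrogen atoms, with the methoxy group kept, a single amino group in place of hydrogen gives an at least 250-fold higher number from compound 1 to compound 4 (2.39 log units; beyond the scatter) in this assay. Compound 4 gives > 20000 nM, which is a limit of the assay and not a number. Compound 2 had shown such a loss only with the methoxy group exchanged, and this result adds a second place on the six-membered ring of the core where one change ends at the same limit: the limit of > 20000 nM in this assay, at which 2 of the 4 values shown sit.

On these data alone, how far the true value of compound 4 lies from that limit stays open, and so does whether a methyl group or a fluorine atom on this carbon would keep the activity of compound 1. Also open, as far as these compounds go, is whether amino here would have the same effect with furan-3-yl in place of thiophen-2-yl.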